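Methyl-to-methoxy swap on the N-aryl ring of the thiazolidinone series

This account rests on a few compounds, and the source may have more. Where it says the series, first, only, none or still open, it means among the compounds named here.

Measured so far:
- compound 1, `COc1ccc(C)cc1N1C(=O)CSC1c1cccc(C(=O)NCCCCc2ccccc2)c1`: 42%
- compound 2, `COc1ccc(OC)c(N2C(=O)CSC2c2cccc(C(=O)NCCCCc3ccccc3)c2)c1`: 5%

In a functional assay on HOS cells (Homo sapiens) for inhibition, read by CCK-8 assay, with a stated time of 72 h, tested at 1 uM (on this read-out higher numbers stand for more inhibition at the one concentration tested (going by the name of the read-out) and lower numbers for less inhibition), compound 1 gives 42% and stands highest of the two numbers available, the nearest being compound 2 with 5%. Among the measured compounds shown here, the one measured step, a number 37 percentage points lower from compound 1 to compound 2 (beyond the scatter), follows a methoxy in place of methyl on an aromatic carbon and is large.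

Compound 3, `COc1ccc(N2C(=O)CSC2c2cccc(C(=O)NCCCCc3ccccc3)c2)c(OC)c1`, is to be measured in this assay. It differs from compound 1 by 2,4-dimethoxyphenyl in place of 2-methoxy-5-methylphenyl on an amide-type nitrogen in a ring. As in the step to compound 2, a methyl on the aryl ring gives way to a methoxy, so the step to compound 2 is the only one that bears on it, although the methoxy now sits at a different place on that ring, and the data do not show how much the position matters.

For the measured compounds named here, a drop is therefore expected, probably smaller than the one seen, given that only one step supports it: for compound 3 the estimate is 15%, between 0% and 40%, that is an expected step of a number 27 percentage points lower from compound 1 to compound 3 (beyond the scatter).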

Compound 3, a percentage reported as inhibition, at one concentration (the size of the read-out at that concentration, not a potency): 82%
For compound 3 the middle estimate is 67 percentage points below the measured one; measured number above the stated range.
By their numbers in this assay, from the lowest: compound 2; then compound 1; then compound 3.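

In this assay, among the compounds shown here, a methoxy in place of the methyl on this ring does not by itself lower the number: the change to 2,4-dimethoxyphenyl from 2-methoxy-5-methylphenyl gives a number 40 percentage points higher from compound 1 to compound 3 (beyond the scatter), the opposite direction to the only earlier step. Compounds 2 and 3 carry the same two methoxy groups on the ring on the amide-type nitrogen and differ only in where one of them sits, yet 2,4-dimethoxyphenyl in place of 2,5-dimethoxyphenyl gives a number 77 percentage points higher from compound 2 to compound 3 (beyond the scatter), so in this pair the arrangement on the ring matters more than the kind of group exchanged, which the step from compound 1 to compound 2 alone could not show. Nothing available on these compounds accounts for this dependence on where the methoxy sits.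

As far as these compounds go, it remains open whether the higher number in this assay is tied to the methoxy itself in the 2,4-dimethoxyphenyl group or would persist with a hydroxyl, a chlorine or an amine in its place. A reading at one concentration also leaves open how compound 3 would behave across a range of concentrations.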